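Cytotoxicity notes: furan-to-pyridine swap on the chloro core

The compounds below may be only part of what the source reports. "The series", "measured", "known", "first", "only" and "open" are said of these compounds alone.

Measured so far:
- compound 1, `O=C(Cn1c(=O)oc2ccccc21)NCc1ccccn1`: 38.7%
- compound 2, `O=C(Cn1c(=O)oc2cc(Cl)ccc21)NCc1ccco1`: 50.3%

In an ADME assay on RAW264.7 cells (Mus musculus) for cytotoxicity, read by MTT assay, with a stated time of 72 h, tested at 100 uM (on this read-out lower numbers stand for a weaker effect and higher numbers for a stronger effect at the one concentration tested), compound 2 stands highest of the two numbers; its nearest neighbour is compound 1, a number lower by more than the scatter. Compound 3, `O=C(Cn1c(=O)oc2cc(Cl)ccc21)NCc1ccccn1`, is not yet measured. It differs from compound 2 by pyridin-2-yl in place of furan-2-yl on a saturated chain carbon bound to an amide-type nitrogen. Going by the values given here, no step between measured compounds isolates this change, so the size of a number 6.3 percentage points lower from compound 2 to compound 3 (within the scatter) is an expectation only, taken as a small decrease not beyond the scatter. Compound 3 is estimated at 44%, with a range from 30% to 60%.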

Compound 3, a percentage reported as inhibition, at one concentration (the size of the read-out at that concentration, not a potency): 40%
Estimate against measurement, compound 3: 4 percentage points above, within the range that was stated.
By their numbers in this assay, from the lowest: compounds 1 and 3 (each within the scatter of the next); then compound 2.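

In this assay the change from furan-2-yl to pyridin-2-yl on a saturated chain carbon bound to an amide-type nitrogen gives a number 10.3 percentage points lower from compound 2 to compound 3 (beyond the scatter) on the shared chloro core, so the read-out responds to this ring. With pyridin-2-yl held fixed, chloro in place of hydrogen on an aromatic carbon gives a number 1.3 percentage points higher from compound 1 to compound 3 (within the scatter) and so makes no difference that can be told from the scatter. No evidence at hand explains the step from furan-2-yl to pyridin-2-yl.

Open, going by these compounds, is whether chloro counts for as little with furan-2-yl on the chain. Also open, on these data alone, is how a phenyl ring or a longer chain ending in an amine would read at this place.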